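Shifting a Fluorine on the Pyridine Tip

The source may report more compounds than this note shows. Statements on the series, on what has been measured and on what is new or still open speak of the compounds shown alone.

Measured so far in an ADME assay on HEK293 cells for agonist activity at metabotropic glutamate receptor 5 (Rattus norvegicus), read by fluorescence and calcium flux; on this read-out lower numbers stand for smaller maximal responses and higher numbers for larger maximal responses:
- compound 1, `C[C@@H](NC(=O)c1ccc(C#Cc2ccccc2F)cn1)C(C)(C)O`, gives 29.6%
- compound 2, `C[C@@H](NC(=O)c1ccc(C#Cc2ccncc2)cn1)C(C)(C)O`, gives 22.4%
- compound 3, `C[C@@H](NC(=O)c1ccc(C#Cc2cccc(F)n2)cn1)C(C)(C)O`, gives 8.3%

All three share one core and differ only in the ring that sits on the triple-bonded carbon. Compound 3 stands lowest of the three in this assay: its nearest neighbour is compound 2, above it by a number 14.1 percentage points lower from compound 2 to compound 3 (beyond the scatter), and compound 1 lies further off by a number 21.3 percentage points lower from compound 1 to compound 3 (beyond the scatter); both gaps are beyond the scatter, while the gap a number 7.2 percentage points lower from compound 1 to compound 2 (within the scatter) is not.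

Compound 4, `C[C@@H](NC(=O)c1ccc(C#Cc2ncccc2F)cn1)C(C)(C)O`, is the next compound. How it differs from compound 3: 3-fluoropyridin-2-yl in place of 6-fluoropyridin-2-yl on a triple-bonded carbon. The two have the same atoms, joined differently.

Within the data shown here, no measured step moves a fluorine within the pyridine ring, so nothing bears directly on this change. The two steps that reach compound 3 show that replacing the earlier rings by 6-fluoropyridin-2-yl lowered the maximal response by modest amounts. Whether 3-fluoropyridin-2-yl behaves like 6-fluoropyridin-2-yl or like the other rings is open; the estimate therefore sits between compound 3 and compound 2. For compound 4 the expected value is 14%, within 4% to 30%, which means an expected step of a number 5.7 percentage points higher from compound 3 to compound 4 (within the scatter).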

Compound 4, largest response reached (reported as efficacy), in percent of the reference or control that the assay uses: 29.2%
Compound 4: middle estimate off by 15.2 percentage points, on the low side; low and high end bracket the measured number.
By their numbers in this assay, from the lowest: compound 3; then compounds 2, 4 and 1 (each within the scatter of the next).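

Within this assay, moving the fluorine around the pyridine ring is enough on its own to change the maximal response, since 3-fluoropyridin-2-yl in place of 6-fluoropyridin-2-yl gives a clear step (a number 20.9 percentage points higher from compound 3 to compound 4 (beyond the scatter)) although the two groups have the same atoms, joined differently. Among these compounds, the low number of compound 3 therefore does not belong to fluoropyridin-2-yl rings in general, and the other two steps (a number 6.8 percentage points higher from compound 2 to compound 4 (within the scatter) and a number 0.4 percentage points lower from compound 1 to compound 4 (within the scatter)) place compound 4 level with the pyridin-4-yl and 2-fluorophenyl compounds, which leaves 6-fluoropyridin-2-yl as the only one of these four rings that stands apart. Nothing measured here explains why the place of the fluorine matters so much.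

As far as these compounds go, it remains open whether a pyridin-2-yl ring without any fluorine, or one carrying a chlorine, a methyl group or a nitrile instead, would fall with compound 3 or with compound 4. From the compounds shown here alone, all four compounds also share one core, so it is unknown whether the same sensitivity would hold if an amine replaced the hydroxyl group on the side chain.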